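The source may report more compounds than this note shows. Statements on the series, on what has been measured and on what is new or still open speak of the compounds shown alone.

Of the compounds shown here, two built on the same core have so far been tested in an ADME assay (liver) for pharmacokinetics, with Liver microsome (Homo sapiens) as the target, using microsomes; on this read-out lower numbers stand for a shorter-lived compound and higher numbers for a longer-lived compound. Compound 1 `CCOc1cc(NC(=O)C2(NC(=O)c3ccc4c(C5CCCC5)c(-c5ncc(Cl)cn5)n(C)c4c3)CCC2)ccc1/C=C/C(=O)OCOP(=O)(O)O` gives 0.167 h. Compound 2 `CCOc1cc(NC(=O)C2(NC(=O)c3ccc4c(C5CCCC5)c(-c5ncc(Cl)cn5)n(C)c4c3)CCC2)ccc1/C=C/C(=O)OCC(=O)N(C)C(C)C` differs from compound 1 only at the far end of the ester chain; in this assay compound 2 gives 0.65 h; the change amounts to a 3.9-fold higher number from compound 1 to compound 2 (0.59 log units; beyond the scatter). Among the compounds with values here, on these two numbers compound 2 stands highest, with compound 1 as its only neighbour.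

Compound 3 `CCOc1cc(NC(=O)C2(NC(=O)c3ccc4c(C5CCCC5)c(-c5ncc(Cl)cn5)n(C)c4c3)CCC2)ccc1/C=C/C(=O)OCC(=O)N1CCOCC1` has not yet been measured. It differs from compound 2 by morpholin-4-yl in place of isopropyl(methyl)amino on a carbonyl carbon. Within the data shown here, no measured step touches this part of the chain: the step from compound 1 to compound 2 swapped the whole group at the end of the ester for an amide chain, which is a different kind of change and offers only a loose guide. With nothing more to go on, the exchange of one amide nitrogen substituent for another is expected to leave this assay result within the usual scatter, a step of no change at the digits printed from compound 2 to compound 3 (within the scatter). The estimate for compound 3 is 0.65 h, with a range from 0.3 h to 1.4 h.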

Compound 3, half-life: 0.667 h
Beside the measured number, compound 3's estimate is 1.0-fold (0.01 log units) below it; the range from low to high includes it.
By their numbers in this assay, from the lowest: compound 1; then compounds 2 and 3 (each within the scatter of the next).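

In this assay, the end of the ester chain accepts a ring: with morpholin-4-yl in place of isopropyl(methyl)amino on the carbonyl carbon, the result is a 1.0-fold higher number from compound 2 to compound 3 (0.01 log units; within the scatter) even though the entering group brings a six-membered non-aromatic ring and a hydrogen-bond acceptor. Compound 3 also repeats what compound 2 showed against compound 1, the phosphorus-bearing compound: the new step is a 4.0-fold higher number from compound 1 to compound 3 (0.60 log units; beyond the scatter) and the earlier one was a 3.9-fold higher number from compound 1 to compound 2 (0.59 log units; beyond the scatter), so among these three compounds the two amides sit together, with none going against that grouping. No supporting measurement is available to explain why the two amides give such closely matched half-lives.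

As far as these compounds go, two amides alone cannot show how wide this tolerance runs, and it remains open whether a piperazine on the same carbonyl carbon, a longer chain before the carbonyl, or a carboxylic acid at the end of the chain would stay with compound 2 and compound 3. The compounds shown also vary only this ester chain, so they say nothing about how changes to the shared core would affect the half-life.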